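A few compounds are considered here, and "the series" means these few. Any claim that something is new, unique, unknown or untested is made for them only; others in the source may bear on it.

Measured in an ADME assay on HepG2 2.2.15 cells (Homo sapiens) for cytotoxicity; a lower number here means that less compound is tolerated, a higher number that more compound is tolerated:
- compound 1 `CCC(=O)OCCc1c(-c2ccccc2Cl)c2cc(Cl)ccc2[nH]c1=O`: 95000 nM
- compound 2 `CC(=O)N1CCC(C(=O)OCCc2c(-c3ccccc3Cl)c3cc(Cl)ccc3[nH]c2=O)CC1`: 82000 nM

Among the compounds with values here, compound 2, at 82000 nM, stands within the scatter of the only other measured compound, and nothing separates the two on these numbers. The next compound to be read is compound 3 `O=C(OCCc1c(-c2ccccc2Cl)c2cc(Cl)ccc2[nH]c1=O)c1ccco1`, which carries furan-2-yl in place of 1-acetylpiperidin-4-yl on a carbonyl carbon. Within the data shown here, one measured step bears on this change, as it alters the group on the same carbonyl carbon: a 1.2-fold lower number from compound 1 to compound 2 (0.06 log units; within the scatter). That step replaced ethyl with 1-acetylpiperidin-4-yl, and it stayed within the scatter. Two compounds are thin support, but no step beyond the scatter is expected in this assay. The expected step is a 1.0-fold higher number from compound 2 to compound 3 (0.02 log units; within the scatter). For compound 3 the estimate is 85000 nM, with an expected range of 40000 nM to 160000 nM.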

Compound 3, half-maximal cytotoxic concentration: 98000 nM
The estimate for compound 3 lay 1.2-fold (0.06 log units) below the measured number; low and high end bracket the measured number.
By their numbers in this assay, from the lowest: compounds 2, 1 and 3 (each within the scatter of the next).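

In this assay, two further readings at this carbonyl carbon are now available: furan-2-yl in place of 1-acetylpiperidin-4-yl (a 1.2-fold higher number from compound 2 to compound 3 (0.08 log units; within the scatter)) and furan-2-yl in place of ethyl (a 1.0-fold higher number from compound 1 to compound 3 (0.01 log units; within the scatter)). The position has now carried a five-membered aromatic ring as well as a six-membered non-aromatic ring and ethyl, and every step among these three compounds stays within the scatter, so an aromatic ring here separates nothing on these numbers. No supporting data offer an explanation for this flat reading.

From the compounds shown here alone, whether a primary amine, a carboxylic acid or a longer alkyl chain on this carbonyl carbon would give a step beyond the scatter remains open. Also open, going by these compounds, is whether changes elsewhere on the shared core, which is the same in all three compounds, would shift the number.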